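A few compounds are considered here, and "the series" means these few. Any claim that something is new, unique, unknown or untested is made for them only; others in the source may bear on it.

Measured compounds and their numbers in an assay on isolated protein for inhibition of leukotriene B4 receptor 1 (Homo sapiens); a higher number here means a weaker inhibitor, a lower number a stronger inhibitor:

compound 1, `CCCc1c(OCCCOc2ccc(C(=O)NC)c(OC)c2CC2CC2)ccc2c1O[C@H](CCC(=O)O)CC2`: 14.5 nM
compound 2, `CCCc1c(OCCCOc2ccc(C(=O)NC)c(OC)c2CC2CC2)ccc2c1OC(C(=O)O)CC2`: 5.3 nM
compound 3, `CCCc1c(OCCCOc2ccc(C(=O)NC)c(OC)c2CC2CC2)ccc2c1OC(CCC(=O)O)CC2`: 10.9 nM

Among these three numbers compound 3 holds the second highest place. Its nearest neighbour is compound 1, and the step of a 1.3-fold lower number from compound 1 to compound 3 (0.12 log units; within the scatter) is within the scatter, so these two compounds are not separated here. Further off lies compound 2, from which the step of a 2.1-fold higher number from compound 2 to compound 3 (0.31 log units; beyond the scatter) is modest.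

The step now followed leads from compound 3 to compound 4, `CCCc1c(OCCCOc2ccc(C(=O)NC)c(OC)c2CC2CC2)ccc2c1O[C@@H](CCC(=O)O)CC2`. The change is the two compounds have the same atoms and bonds; at least one stereo element is drawn with a configuration in one of them and without one in the other: 1 of 1 stereo elements differ; a stereocentre at a saturated ring carbon is drawn without a configuration in compound 3 and R in compound 4. Among the measured compounds shown here, only one of the measured steps bears on it: the step from compound 1 to compound 3, where the fact that one of compounds 1 and 3 is drawn with a defined configuration and the other without, at the place where they differ is the same kind of difference, and that step came out at a 1.3-fold lower number from compound 1 to compound 3 (0.12 log units; within the scatter), within the scatter. Compound 4 carries the configuration not drawn in compound 1, so the measured step gives no firm size for the change in this assay; the expectation is a small step, if any, and more likely toward a lower number than toward a higher one, with the outcome uncertain.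

Compound 4 is therefore estimated at 8 nM, with a range from 3 nM to 30 nM, which means an expected step of a 1.4-fold lower number from compound 3 to compound 4 (0.13 log units; within the scatter).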

Compound 4, half-maximal inhibitory concentration: 8.5 nM
Compound 4: middle estimate off by 1.1-fold (0.03 log units), on the low side, within the range that was stated.
By their numbers in this assay, from the lowest: compounds 2, 4, 3 and 1 (each within the scatter of the next, the first and the last beyond it).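

Among the compounds shown here, this is the first direct comparison in this assay of the two drawn configurations at the saturated ring carbon that carries the 2-carboxyethyl group, and only one thing separates the pair: the fact that compounds 1 and 4 differ only in the configuration as drawn. That comparison gives a 1.7-fold lower number from compound 1 to compound 4 (0.23 log units; within the scatter), so S and R at this carbon are not separated here, and the earlier step could not show this, as it set a single drawn configuration against a form drawn without one. The remaining comparison, with a 1.3-fold lower number from compound 3 to compound 4 (0.11 log units; within the scatter), likewise shows no separation, so the form drawn without a configuration cannot be told apart from either drawn configuration in this assay.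

The compounds shown leave open whether configuration at this carbon would also go unseparated with the carboxy group of compound 2, which is drawn only without a configuration, or with a longer chain such as 3-carboxypropyl. They also leave open how this assay would read if a primary amide or a tetrazole took the place of the carboxylic acid on the 2-carboxyethyl chain, in either configuration.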